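Urea aryl variation and dopamine transporter inhibition

The source may report more compounds than this note shows. Statements on the series, on what has been measured and on what is new or still open speak of the compounds shown alone.

Going by the values given here, compound 3 `Cc1ccc(NC(=O)NCCCCC(c2ccc(F)cc2)c2ccc(F)cc2)cc1C` gives 79% in an ADME assay on isolated protein for inhibition of sodium-dependent dopamine transporter (Homo sapiens), tested at 10 uM (a higher number here means more inhibition at the concentration tested (going by the name of the read-out), a lower number less inhibition), and stands second highest of the three numbers so far; nearest is compound 2 `CC(=O)Nc1cc(NC(=O)NCCCCC(c2ccc(F)cc2)c2ccc(F)cc2)ccc1Cl` with 76%, a gap within the scatter, and furthest is compound 1 `O=C(NCCCCC(c1ccc(F)cc1)c1ccc(F)cc1)Nc1ccc(Cl)c(C(F)(F)F)c1` with 90%. Compound 4 `O=C(NCCCCC(c1ccc(F)cc1)c1ccc(F)cc1)Nc1ccc(Cl)cc1C(F)(F)F` differs from compound 3 by 4-chloro-2-(trifluoromethyl)phenyl in place of 3,4-dimethylphenyl on an amide-type nitrogen. The step that bears on this change is a number 11 percentage points lower from compound 1 to compound 3 (beyond the scatter), in which 3,4-dimethylphenyl replaced 4-chloro-3-(trifluoromethyl)phenyl; compound 4 brings a chlorine and a trifluoromethyl back onto that ring, now as 4-chloro-2-(trifluoromethyl)phenyl. Among the compounds with values here, a modest rise is therefore expected, a number 6 percentage points higher from compound 3 to compound 4 (within the scatter), with some uncertainty since the entering group is not the one in compound 1. Compound 4 is estimated at 85%, in a range from 72% to 95%.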

Compound 4, a percentage reported as inhibition, at one concentration (the size of the read-out at that concentration, not a potency): 20%
Compound 4: middle estimate off by 65 percentage points, on the high side; measured number outside the range, below it.
By their numbers in this assay, from the lowest: compound 4; then compounds 2 and 3 (each within the scatter of the next); then compound 1.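

In this assay the same substituents on the ring do not give the same outcome: 4-chloro-2-(trifluoromethyl)phenyl in place of 4-chloro-3-(trifluoromethyl)phenyl gives a number 70 percentage points lower from compound 1 to compound 4 (beyond the scatter), so at this amide-type nitrogen the arrangement of chlorine and trifluoromethyl counts, not merely their presence. Going by these compounds alone, the other two steps are of similar size, a number 59 percentage points lower from compound 3 to compound 4 (beyond the scatter) and a number 56 percentage points lower from compound 2 to compound 4 (beyond the scatter), far larger than any step among the earlier compounds. Nothing available explains the drop.

Still open, from the compounds shown here alone, is whether the trifluoromethyl of 4-chloro-2-(trifluoromethyl)phenyl is what matters, or whether a methyl or a methoxy at that place would give the same low number. Also open, going by these compounds, is whether an amine or a carboxylic acid on this ring would restore inhibition.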